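Shortening the phenyl-ended chain of compound 2

The compounds below may be only part of what the source reports. "The series", "measured", "known", "first", "only" and "open" are said of these compounds alone.

For the measured compounds named here, only two compounds carry numbers so far. In a functional assay on NCI-H630 cells (Homo sapiens) for cytotoxicity, read by sulforhodamine B assay, with a stated time of 5 days (on this read-out lower numbers stand for stronger inhibition and higher numbers for weaker inhibition), compound 1 `O=C(CCCCCCc1ccccc1)CC(=O)N[C@H]1CCOC1=O` gives 65000 nM and compound 2 `O=C(CCCCCCCCCCc1ccccc1)CC(=O)N[C@H]1CCOC1=O` gives 23000 nM. Compound 2 therefore holds the lower of the two numbers, and its gap to compound 1 lies beyond the usual scatter. Going by the values given here, no measured pair differs in one place only, so no single structural step has yet been observed directly.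

The next compound is compound 3 `O=C(CCCCCCCc1ccccc1)CC(=O)N[C@H]1CCOC1=O`, which keeps the shared core of compound 2. The change is phenyl in place of 3-phenylpropyl on a saturated chain carbon, seven bonds along the chain from a carbonyl carbon.

A modest rise in the number is expected in this assay, meaning weaker inhibition. This expectation rests on the higher number of compound 1 at 65000 nM, and two measured compounds make only a thin basis for it. The expected change is a 2.1-fold higher number from compound 2 to compound 3 (0.32 log units; beyond the scatter). For compound 3 the estimated value is 48000 nM, with an estimated range of 22000 nM to 95000 nM.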

Compound 3, half-maximal inhibitory concentration: 42000 nM
Compound 3: middle estimate off by 1.1-fold (0.06 log units), on the high side; measured number inside the range.
By their numbers in this assay, from the lowest: compounds 2, 3 and 1 (each within the scatter of the next, the first and the last beyond it).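

In this assay, phenyl in place of 3-phenylpropyl on a saturated chain carbon, seven bonds along the chain from a carbonyl carbon, gives a 1.8-fold higher number from compound 2 to compound 3 (0.26 log units; within the scatter) as a step within the scatter, so this change of chain length has no resolved effect on the number. Benzyl in place of phenyl on a saturated chain carbon, six bonds along the chain from a carbonyl carbon, gives a 1.5-fold lower number from compound 1 to compound 3 (0.19 log units; within the scatter) and also stays within the scatter, so neither single step at this position separates compound 3 from the compound it is paired with. For the compounds shown here, nothing measured so far gives a cause for either step.

Open, from the compounds shown here alone, is whether a much shorter chain, or a chain ending in a cyclohexyl ring or a carboxylic acid instead of the phenyl ring, would move the number beyond the scatter. Also open is whether an amine placed on the chain would change the number in this assay at all, since every compound shown carries an unbroken carbon chain ending in phenyl.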